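The source may hold more compounds than are shown below. What is called first, only, known or untested is meant among the compounds shown, and "the series" means these compounds.

Measured compounds in a toxicity assay on MRC5 cells (Homo sapiens) for cytotoxicity, read by MTT assay, with a stated time of 24 h; on this read-out higher numbers stand for weaker inhibition and lower numbers for stronger inhibition:
compound 1, `[N-]=[N+]=Nc1cc2cc(Cl)cc(Cl)c2oc1=O` — 67200 nM
compound 2, `COc1cccc2cc(-n3nnc4c3-c3ccccc3N(C(=O)CCN)Cc3ccccc3-4)c(=O)oc12` — 92800 nM

Two compounds carry a number in this assay. Compound 1 gives 67200 nM and compound 2 gives 92800 nM. Compound 2 has the higher of the two numbers, but the gap to compound 1 lies within the usual scatter, so the two values do not separate and neither compound can be called the weaker or the stronger inhibitor on this read-out. Among the measured compounds shown here, the two compounds share a coumarin-type fragment but otherwise differ in many places at once, so no single structural step connects them.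

Compound 3, `NCCC(=O)N1Cc2ccccc2-c2nnn(-c3cc4ccccc4oc3=O)c2-c2ccccc21`, is the next compound in line and remains to be measured. It differs from compound 2 in one place: hydrogen in place of methoxy on an aromatic carbon. For the measured compounds named here, no pair of measured compounds shows this change, so there is no observed step to lean on. With compound 2 at 92800 nM and nothing in the data pointing either way, the expected step is none beyond the scatter. The estimated step from compound 2 to compound 3 is a 1.0-fold lower number from compound 2 to compound 3 (0.01 log units; within the scatter). Compound 3 is therefore expected to fall at about 90000 nM, with a range of 40000 nM to 200000 nM; a result given only as an assay limit is also plausible at this level.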

Compound 3, half-maximal inhibitory concentration: 110000 nM
Estimate against measurement, compound 3: 1.2-fold (0.09 log units) below, within the range that was stated.
By their numbers in this assay, from the lowest: compounds 1, 2 and 3 (each within the scatter of the next).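

In this assay, among the compounds shown here, hydrogen in place of methoxy on an aromatic carbon gives a 1.2-fold higher number from compound 2 to compound 3 (0.07 log units; within the scatter) and provides the first step that changes one place only. At this position, ortho to a fused ring and meta to a fused ring, removing methoxy therefore leaves compound 2 and compound 3 unseparated on this read-out, so the pair gives no sign that the methoxy group is needed for the number seen with compound 2. No measurement of any other kind bears on this result.

Only hydrogen and methoxy are shown at this place, so it remains open whether a fluorine atom, a carboxylic acid or a dimethylamino group there would give a step beyond the scatter. From the compounds shown here alone, it is also open whether the flat result holds for the same change with a longer chain on the amide carbonyl, and whether any change in the shared core would separate compounds in this assay at all.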